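The source may report more compounds than this note shows. Statements on the series, on what has been measured and on what is new or still open speak of the compounds shown alone.

Working notes on the series.

Two compounds have been run in a functional assay on the whole organism (strain Swiss albino) for inhibition, with Mus musculus as the target, read by paw edema, with stated times of 30 min and 360 min, at a dose of 100 mg/kg by the subcutaneous route; a higher number here means more inhibition at the dose given (going by the name of the read-out), a lower number less inhibition. Compound 1, `CCOC(=O)C1CCN(C(=O)c2cc(-c3ccc(C)cc3)n(Cc3ccccc3)n2)CC1`, gives 59.8% in this assay. Compound 2, `Cc1ccc(-c2cc(C(=O)Oc3ccc(C(C)(C)C)cc3)nn2Cc2ccccc2)cc1`, gives 58.7% in this assay. Compound 2 stands lowest of the two numbers, but its nearest neighbour is compound 1, whose number is higher by an amount within the usual scatter, so the two cannot be ordered on these data. Within the data shown here, no pair of measured compounds differs in one place, so no measured step is available as a yardstick.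

The next compound, compound 3, is `Cc1ccc(-c2cc(C(=O)Oc3ccc(C(C)C)cc3)nn2Cc2ccccc2)cc1`, not yet run in this assay. It differs from compound 2 in one place: hydrogen in place of methyl on a saturated chain carbon bound to an aromatic carbon and two saturated chain carbons. The change is small, a single carbon, with no ring and no change in donors, acceptors or charge.

Among the measured compounds shown here, with no measured step of this kind, the step from compound 2 to compound 3 is expected to be none beyond the scatter, a number 2.7 percentage points lower from compound 2 to compound 3 (within the scatter). Compound 3 is therefore estimated at 56% in this assay, with a range from 42% to 68%, the wide range reflecting that the expectation rests on compound 2 alone at 58.7%.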

Compound 3, a percentage reported as inhibition, in the whole organism at one dose (the size of the read-out at that dose, not a potency): 47.8%
Compound 3: middle estimate off by 8.2 percentage points, on the high side; the range from low to high includes it.
By their numbers in this assay, from the lowest: compound 3; then compounds 2 and 1 (each within the scatter of the next).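

In this assay, among these compounds, the change from tert-butyl to isopropyl gives a number 10.9 percentage points lower from compound 2 to compound 3 (beyond the scatter), the first measured step and a modest one. It shows that this position, a saturated chain carbon bound to an aromatic carbon and two saturated chain carbons, is not silent: the loss of a single methyl, with no ring, donor, acceptor or charge involved, is enough to move the read-out beyond the scatter, and the tert-butyl form of the pair holds the higher number at this one dose. Nothing measured on these compounds accounts for the size or direction of the step.

Open, on these data alone, is how the read-out behaves along the rest of this line: whether 4-ethylphenyl, 4-methylphenyl or plain phenyl continues downward from 4-isopropylphenyl, or whether a cyclohexyl or trifluoromethyl group at the same place matches 4-(tert-butyl)phenyl. Also open, as far as these compounds go, is whether the same change gives a similar step on the piperidine-free parent alone or also in the setting of compound 1, which differs from compound 2 and compound 3 in more than one place and so offers no direct comparison.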